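Does the Methoxy Group Matter for Growth Inhibition?

A few compounds are considered here, and "the series" means these few. Any claim that something is new, unique, unknown or untested is made for them only; others in the source may bear on it.

Compound 1, `COc1ccc(-n2nc(-c3ccc4ccccc4c3)nc2N2C(=O)COC23C=CC(=O)C=C3)cc1`: 60 nM
Compound 2, `CC1OC2(C=CC(=O)C=C2)N(c2nc(-c3cccc4ccccc34)nn2-c2ccccc2)C1=O`: 100 nM
Compound 3, `O=C1C=CC2(C=C1)OCC(=O)N2c1nc(-c2ccc3c(c2)OCCO3)nn1-c1ccccc1`: 100 nM

The three compounds above were tested in a functional assay on MDA-MB-231 cells (Homo sapiens) for antiproliferative activity, with a stated time of 5 days; a higher number here means a weaker inhibitor, a lower number a stronger inhibitor. Compound 1 gives the lowest of the three numbers, but its gap to compound 2 and its gap to compound 3 are both within the usual scatter of such measurements, so the three compounds cannot be ranked against one another on these data. Compound 2 and compound 3 each carry a phenyl on the shared core where compound 1 carries a methoxy-bearing ring, and they differ from compound 1 in other places as well, so none of them isolates a single change.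

Compound 4, `O=C1C=CC2(C=C1)OCC(=O)N2c1nc(-c2ccc3ccccc3c2)nn1-c1ccccc1`, differs from compound 1 in exactly one place: hydrogen in place of methoxy on an aromatic carbon. For the measured compounds named here, no pair among the measured compounds shows the effect of this change on its own. Given that the measured values all sit close together, the step from compound 1 to compound 4 is expected to be small, most likely none beyond the scatter, with a slight lean towards a higher number: a 1.5-fold higher number from compound 1 to compound 4 (0.18 log units; within the scatter). Compound 4 is therefore estimated to give 90 nM in this assay, within a range from 40 nM to 220 nM.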

Compound 4, half-maximal inhibitory concentration: 70 nM
Compound 4: middle estimate off by 1.3-fold (0.11 log units), on the high side, and the stated range covers the measured number.
By their numbers in this assay, from the lowest: compounds 1, 4, 2 and 3 (each within the scatter of the next).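

In this assay, for the compounds shown here, the step with hydrogen in place of methoxy, the change that reads 4-methoxyphenyl to phenyl, is a 1.2-fold higher number from compound 1 to compound 4 (0.07 log units; within the scatter) and gives the first view of this group on its own. On this aromatic carbon, para to a large group, the compounds with and without the methoxy group cannot be told apart, so this assay shows no need for the methoxy group in this pair. A second single change, naphthalen-2-yl in place of 2,3-dihydro-1,4-benzodioxin-6-yl on an aromatic carbon, is a 1.4-fold lower number from compound 3 to compound 4 (0.15 log units; within the scatter) and likewise leaves the two compounds indistinguishable, while no other measurement here bears on either result.

The compounds shown cover only hydrogen and methoxy on that ring, so it remains open whether an amine, a carboxylic acid or a longer chain such as butoxy in the same place would give a step beyond the scatter. Going by these compounds, both pairs also come from a single cell line, so whether these results hold in other cells remains open too.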